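This account rests on a few compounds, and the source may have more. Where it says the series, first, only, none or still open, it means among the compounds named here.

Compound 1 `CCC1Oc2ccc(Cl)cc2N(O)C1=O` gives 400 nM in a functional assay on the whole organism for inhibition, with Lepidium sativum as the target, with a stated time of 4 days (a lower number here means a stronger inhibitor, a higher number a weaker inhibitor), the highest of the three numbers in hand. Compound 2 `CCCCC(=O)ON1C(=O)COc2ccc(Cl)cc21` gives 60 nM and compound 3 `CCCON1C(=O)COc2ccc(Cl)cc21` gives 60 nM, each beyond the scatter from compound 1. Among the measured compounds shown here, the only single-point step measured so far, no change at the digits printed from compound 2 to compound 3 (within the scatter), concerns the substituent on an oxygen and leaves the aromatic ring untouched, so it does not bear on the change considered here. Compound 4 `CCC1Oc2ccc(F)cc2N(O)C1=O` differs from compound 1 by fluoro in place of chloro on an aromatic carbon. For the measured compounds named here, no measured step addresses this exchange, and the series offers no precedent for its direction. The expected step in this assay is therefore a 1.5-fold higher number from compound 1 to compound 4 (0.18 log units; within the scatter), within the scatter. Compound 4 is estimated at 600 nM, with a range from 200 nM to 1800 nM.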

Compound 4, half-maximal inhibitory concentration: 1000 nM
Compound 4: middle estimate off by 1.7-fold (0.22 log units), on the low side, and the stated range covers the measured number.
By their numbers in this assay, from the lowest: compounds 2 and 3 (each within the scatter of the next); then compound 1; then compound 4.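

In this assay, among the compounds shown here, the aromatic carbon carrying the halogen is sensitive to this exchange: fluoro in place of chloro gives a 2.5-fold higher number from compound 1 to compound 4 (0.40 log units; beyond the scatter), the only measured step at this position, and it runs towards weaker inhibition. On the core of compound 1, chloro therefore gives the stronger inhibitor of the two halogens, although this rests on a single pair. No evidence at hand explains the step. Open, from the compounds shown here alone, is whether bromo, methyl or methoxy at this position would lower the number, and whether the same exchange carries over to the acylated or alkylated oxygen of compound 2 or compound 3.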